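The compounds below may be only part of what the source reports. "The series", "measured", "known", "first", "only" and "open" are said of these compounds alone.

Measured compounds:
Compound 1 `COc1cccc(N2CCN(c3c(CO)c(=O)oc4ccccc34)CC2)c1` gives 38100 nM in a functional assay on WM1361 cells (Homo sapiens) for inhibition, read by MTT assay, with a stated time of 24 h; on this read-out lower numbers stand for stronger inhibition and higher numbers for weaker inhibition.
Compound 2 `O=c1oc2ccccc2c(N2CCN(c3ccccc3F)CC2)c1CO` gives > 50000 nM in this assay; that value is a limit of the assay rather than a number.

For the measured compounds named here, compound 1 carries the only actual number in this assay; the one other value shown is a limit. The step of an at least 1.3-fold higher number from compound 1 to compound 2 (0.11 log units; that floor lies within the scatter) is 2-fluorophenyl in place of 3-methoxyphenyl on an amine nitrogen in a ring; it ends at the limit of > 50000 nM in this assay, at which 1 of the 2 values shown sits, and its floor lies inside the scatter, so it establishes no change that can be relied on.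

Compound 3 `CCN1CCN(c2c(CO)c(=O)oc3ccccc23)CC1` differs from compound 1 by ethyl in place of 3-methoxyphenyl on an amine nitrogen in a ring. Going by the values given here, no measured step covers the exchange of an aromatic group for a short chain on that nitrogen; the single step from compound 1 to compound 2 only swaps one aromatic group for another and stops at the limit. On that basis compound 3 is expected to sit near compound 1, with a real chance that this assay reports only a limit. The expected step is a 1.2-fold higher number from compound 1 to compound 3 (0.07 log units; within the scatter). Compound 3 is estimated at 45000 nM, range 15000 nM to 150000 nM.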

Compound 3, half-maximal inhibitory concentration: > 100000 nM
Compound 3 ended at the assay's limit; the forecaster's own chance of this, stated with the estimate: 45%; middle value at least 2.2-fold (0.34 log units) away from the limit.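

In this assay, for the compounds shown here, ethyl in place of 3-methoxyphenyl on this ring nitrogen gives an at least 2.6-fold higher number from compound 1 to compound 3 (0.41 log units; beyond the scatter) and is the first step that is beyond the scatter. Going by these compounds alone, the result gives this position a readable dependence on the group it carries, which the exchange of one aromatic group for another did not provide; the 3-methoxyphenyl of compound 1 remains the only group here with an actual number, and compound 2 shows that keeping an aromatic ring on this nitrogen does not by itself secure one. The value of compound 3 is a limit of the assay and not a number, so the step gives only a floor for the change and not its full size: the limit of > 100000 nM in this assay, at which 1 of the 3 values shown sits.

The step between compound 2 and compound 3 cannot be read, as both values are limits, so ethyl and 2-fluorophenyl cannot be placed in order. Open too, going by these compounds, is whether a benzyl group, or a longer chain ending in an amine or a carboxylic acid, on this nitrogen would bring a number back into range.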